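Aryl-hydroxamate chain series against histone deacetylase 8

The source may report more compounds than this note shows. Statements on the series, on what has been measured and on what is new or still open speak of the compounds shown alone.

Measured compounds:
compound 1 `COc1ccc(C(=O)CCCCCCC(=O)NO)cc1`: 450 nM
compound 2 `COc1ccc(C(=O)CCCCCCCC(=O)NO)cc1`: 15 nM
compound 3 `O=C(CCCCCCC/C(=N\O)c1ccc(-c2ccccc2)cc1)NO`: 4 nM

In an assay on isolated protein for inhibition of histone deacetylase 8 (Homo sapiens) (on this read-out higher numbers stand for weaker inhibition and lower numbers for stronger inhibition), compound 2 gives 15 nM, the second highest of the three numbers. Its nearest neighbour is compound 3, which in this assay gives 4 nM; compound 1 stands furthest away with 450 nM. Among the measured compounds shown here, the one single-site step recorded, a 30-fold lower number from compound 1 to compound 2 (1.48 log units; beyond the scatter), concerns the chain and not the aryl end.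

Compound 4 `O=C(CCCCCCCC(=O)c1ccc(-c2ccc(Br)cc2)cc1)NO` differs from compound 2 in one place: 4-bromophenyl in place of methoxy on an aromatic carbon. For the measured compounds named here, no measured step touches this exchange. Going by the values given here, the only pointer is compound 3, whose aryl end also carries a second phenyl ring and which gives the lowest number of the set, although it differs from compound 2 in the chain linkage as well, so its reading cannot be carried over directly. On this basis a moderate step toward a lower number is expected from compound 2 to compound 4, of the order of a 2.1-fold lower number from compound 2 to compound 4 (0.33 log units; beyond the scatter), with the range kept wide given the absence of a matching step.

Compound 4 is therefore estimated at 7 nM in this assay, between 2 nM and 30 nM.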

Compound 4, half-maximal inhibitory concentration: 2 nM
Compound 4: the middle estimate sits 3.5-fold (0.54 log units) above what was measured; low and high end bracket the measured number.
By their numbers in this assay, from the lowest: compounds 4 and 3 (each within the scatter of the next); then compound 2; then compound 1.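

In this assay, among the compounds shown here, the exchange of methoxy for 4-bromophenyl on the aromatic carbon gives a 7.5-fold lower number from compound 2 to compound 4 (0.88 log units; beyond the scatter), the only measured single-site step at the aryl end of the series. For the compounds shown here, until now the one such step lay in the chain, so this result shows that the aryl end can also move the number beyond the scatter, and that a group carrying a six-membered aromatic ring of carbon only can replace methoxy without loss in this assay, even though the one hydrogen-bond acceptor of methoxy is gone. No available evidence explains the size or direction of this step.

The exchange adds a ring and a bromine together, so the compounds shown cannot divide the step between them; an unsubstituted phenyl or a 4-chlorophenyl at this position would separate the two contributions. Also open is whether the chain step, a 30-fold lower number from compound 1 to compound 2 (1.48 log units; beyond the scatter), holds with 4-bromophenyl at the aryl end, as would be shown by the shorter-chain partner of compound 4 carrying the same group.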